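The compounds below may be only part of what the source reports. "The series", "measured", "known", "first", "only" and "open" are said of these compounds alone.

Measured compounds:
- Compound 1, `CCSc1nc(=O)ccn1[C@@H]1O[C@H](COP(=O)(O)O)[C@@H](O)[C@H]1O`: 1500 nM
- Compound 2, `O=c1[nH]c(=S)ccn1[C@@H]1O[C@H](COP(=O)(O)O)[C@@H](O)[C@H]1O`: > 100000 nM

Going by the values given here, in an in vitro functional assay on 1321-N1 cells for agonist activity at P2Y purinoceptor 2 (Homo sapiens), read by scintillation proximity assay and inositol phosphate accumulation (a lower number here means that less compound is needed, a higher number that more compound is needed for the effect), compound 1 gives 1500 nM, and this is the only plain number in the set. For compound 2, > 100000 nM is a limit of the assay rather than a number, so its potency is known only to lie beyond that limit (the limit of > 100000 nM in this assay, at which 1 of the 2 values shown sits). Compound 1 therefore stands alone as the single measured point from which anything can be read.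

Compound 3, `CCCSc1nc(=O)ccn1[C@@H]1O[C@H](COP(=O)(O)O)[C@@H](O)[C@H]1O`, has not yet been tested. It differs from compound 1 by one small change: methyl in place of hydrogen on a saturated chain carbon, two bonds along the chain from a sulfur. Among the compounds with values here, because no pair of measured compounds differs in a single place, there is no measured step to show how this kind of extension behaves. The change is small, and with only one reference point the expectation is a modest step in this assay, possibly in either direction, and likely no larger than the usual scatter.

Compound 3 is therefore expected to give about 1000 nM, within a range from 300 nM to 4000 nM, which amounts to an estimated step of a 1.5-fold lower number from compound 1 to compound 3 (0.18 log units; within the scatter).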

Compound 3, half-maximal effective concentration: 4800 nM
Compound 3: the middle estimate sits 4.8-fold (0.68 log units) below what was measured; measured number above the stated range.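

In this assay, lengthening the ethylsulfanyl group of compound 1 to the propylsulfanyl group of compound 3 amounts to a 3.2-fold higher number from compound 1 to compound 3 (0.51 log units; beyond the scatter). Going by these compounds alone, this is the first measured step in the set, and it shows that the saturated chain on the sulfur is not a place where added carbon goes unnoticed: a single methyl in place of hydrogen, two bonds along the chain from the sulfur, is enough to move the number beyond the usual scatter, towards more compound being needed for the effect. Nothing among the results shown bears on why this single added methyl has that effect.

One step cannot show whether the number would keep rising with a longer chain such as butylsulfanyl, or whether a shorter methylsulfanyl group would need less compound than compound 1. It also leaves open how this position would respond to something other than a plain straight chain, such as a benzyl group, or a chain carrying an amine or a carboxylic acid.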